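The source may report more compounds than this note shows. Statements on the series, on what has been measured and on what is new or still open speak of the compounds shown alone.

Of the compounds shown here, three sharing one core have been measured in an assay on isolated protein for inhibition of RAC-alpha serine/threonine-protein kinase (Homo sapiens); on this read-out higher numbers stand for weaker inhibition and lower numbers for stronger inhibition. Compound 1 `Cc1cccc(C)c1S(=O)(=O)N1CCC[C@@H]1[C@@H](O)CN1CCC[C@@]2(CCN(c3ncnc(N)c3C3CC3)C2)C1` gives 19 nM in this assay. Compound 2 `Cc1cccc(C)c1S(=O)(=O)NC[C@@H](O)CN1CCC[C@@]2(CCN(c3ncnc(N)c3C3CC3)C2)C1` gives 4 nM in this assay. Compound 3 `Nc1ncnc(N2CC[C@@]3(CCCN(C[C@H](O)CNS(=O)(=O)c4ccccc4F)C3)C2)c1C1CC1` gives 81 nM in this assay, the highest of the three numbers; the nearest is compound 1 and the furthest is compound 2. Among the compounds with values here, the one single-point step among them, a 20-fold higher number from compound 2 to compound 3 (1.31 log units; beyond the scatter), shows that the group on the sulfonyl sulfur sets a large part of the outcome.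

Compound 4 `Nc1ncnc(N2CC[C@@]3(CCCN(C[C@H](O)CNS(=O)(=O)c4ccccc4Br)C3)C2)c1C1CC1` is the next step from compound 3. The change is bromo in place of fluoro on an aromatic carbon, on an aromatic carbon of a six-membered aromatic ring of carbon only, ortho to a large group; read one bond further out it is 2-fluorophenyl to 2-bromophenyl. Within the data shown here, no measured step exchanges one halogen for another, so the direction rests only on the step from compound 2 to compound 3, which showed that what sits on that ring matters. A modest step toward a lower number is therefore expected, as a 2.3-fold lower number from compound 3 to compound 4 (0.36 log units; beyond the scatter), with a wide range. Compound 4 is estimated at 35 nM in this assay, between 8 nM and 150 nM.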

Compound 4, half-maximal inhibitory concentration: 17 nM
Estimate against measurement, compound 4: 2.1-fold (0.31 log units) above, within the range that was stated.
By their numbers in this assay, from the lowest: compound 2; then compounds 4 and 1 (each within the scatter of the next); then compound 3.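

Exchanging one halogen for another at this place on the ring is enough on its own to shift the result in this assay, with a 4.8-fold lower number from compound 3 to compound 4 (0.68 log units; beyond the scatter), so the earlier finding that the sulfonyl group matters now extends to a single atom on its aromatic ring. The change recovers only part of the loss seen in a 20-fold higher number from compound 2 to compound 3 (1.31 log units; beyond the scatter), since the 2-bromophenyl group still falls short of the 2,6-dimethylphenyl group, with a 4.3-fold higher number from compound 2 to compound 4 (0.63 log units; beyond the scatter), and both of these steps are beyond the scatter. Nothing available explains why bromo and fluoro differ here, or why neither matches the 2,6-dimethylphenyl group.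

The compounds shown leave open how a 2-chlorophenyl, a 2-methylphenyl or an unsubstituted phenyl group would read on the same sulfonyl sulfur, and so whether the outcome follows the single group on the ring or depends on having a second one. On these data alone, it also remains open whether a methoxy or a trifluoromethyl group on that aromatic carbon would follow bromo or fluoro, or a 2,6-dibromophenyl group would follow the 2,6-dimethylphenyl group.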